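Chloro for ethyl on the aryl ether of a TRPM8 agonist amide

This account rests on a few compounds, and the source may have more. Where it says the series, first, only, none or still open, it means among the compounds named here.

Three amides of the shared core have numbers in an assay on HEK293 cells for agonist activity at transient receptor potential cation channel subfamily M member 8 (Homo sapiens), read by fluorescence and calcium flux, with a stated time of 15 min; a lower number here means that less compound is needed, a higher number that more compound is needed for the effect. Compound 1 `CCc1ccc(OCC(=O)N(CC)Cc2cccs2)cc1` gives 67 nM, the lowest of the three. Compound 3 `Cc1ccc(OCC(=O)N(C)Cc2cccs2)cc1` gives 400 nM, a gap from compound 1 beyond the scatter, while compound 2 `CCN(Cc1cccs1)C(=O)C(C)Oc1ccc(C)cc1` gives 889 nM, the widest gap from compound 1 and also beyond the scatter. For the measured compounds named here, compound 3 and compound 2 each differ from compound 1 in more than one place, so no single step between measured compounds is available to calibrate the change now examined.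

Compound 4 `CCN(Cc1cccs1)C(=O)COc1ccc(Cl)cc1` differs from compound 1 in one place: chloro in place of ethyl on an aromatic carbon, the chloro sitting on an aromatic carbon of a six-membered aromatic ring of carbon only, para to a large group. Going by the values given here, with no measured pair to anchor this exchange, the step from compound 1 to compound 4 is expected to be modest, toward a somewhat higher number, and may fall within the scatter, a 1.6-fold higher number from compound 1 to compound 4 (0.22 log units; within the scatter). Compound 4 is therefore estimated at 110 nM in this assay, with a range from 40 nM to 300 nM.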

Compound 4, half-maximal effective concentration: 39 nM
For compound 4 the middle estimate is 2.8-fold (0.45 log units) above the measured one; the measured number lies below the stated range.
By their numbers in this assay, from the lowest: compounds 4 and 1 (each within the scatter of the next); then compound 3; then compound 2.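

In this assay, chloro in place of ethyl on an aromatic carbon, para to a large group, gives a 1.7-fold lower number from compound 1 to compound 4 (0.24 log units; within the scatter) and so leaves compound 1 and compound 4 indistinguishable. This first single-place step in the series shows that ethyl is not required at this position to keep the number in this range, since the smaller chloro serves within the scatter. Nothing on hand offers an explanation for this match between chloro and ethyl.

On these data alone, whether this tolerance extends to other groups at the position, such as methoxy, nitrile, trifluoromethyl or a longer chain such as propyl, remains open. As far as these compounds go, the separate effects of the other changes in compound 2 and compound 3 also remain open, as each differs from compound 1 in more than one place.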